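A few compounds are considered here, and "the series" means these few. Any claim that something is new, unique, unknown or untested is made for them only; others in the source may bear on it.

Compound 2 `COc1ccc(/C=C\c2cc(OC)c(OC)c(OC)c2)cc1OCc1ccc(CN2C[C@H](O)C[C@@H]2C(=O)O)cc1` stands at the edge of what a functional assay on HepG2 cells (Homo sapiens) for antiproliferative activity, read by CCK-8 assay, with a stated time of 48 h (a higher number here means a weaker inhibitor, a lower number a stronger inhibitor), can report: in this assay compound 2 gives > 10000 nM, which is a limit rather than a number. Compound 1 `COc1ccc(/C=C\c2cc(OC)c(OC)c(OC)c2)cc1OCc1ccc(CN2CC(C(=O)O)C2)cc1` gives > 10000 nM in this assay, likewise only a limit. Among the compounds with values here, compound 3 `COc1ccc(/C=C\c2cc(OC)c(OC)c(OC)c2)cc1OCc1ccc(CN2CC[C@@H](C(=O)O)C2)cc1` is the one compound with a number, giving 2300 nM in this assay. Compound 4 `COc1ccc(/C=C\c2cc(OC)c(OC)c(OC)c2)cc1OCc1ccc(CN2CC[C@H](O)C2)cc1` carries 3-hydroxypyrrolidin-1-yl in place of 2-carboxy-4-hydroxypyrrolidin-1-yl on a saturated chain carbon bound to an aromatic carbon. Within the data shown here, two measured steps touch on this change, an at least 4.3-fold lower number from compound 2 to compound 3 (0.63 log units; beyond the scatter) and an at least 4.3-fold lower number from compound 1 to compound 3 (0.63 log units; beyond the scatter), both starting from the limit of > 10000 nM in this assay, at which 2 of the 3 values shown sit. Neither of them removes the carboxy group outright, so the size of the present step is only loosely bounded. Compound 4 is nonetheless expected to leave the limit, with an estimated step of an at least 6.6-fold lower number from compound 2 to compound 4 (0.82 log units; beyond the scatter). Compound 4 is estimated at 1500 nM, within 300 nM to 10000 nM.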

Compound 4, half-maximal inhibitory concentration: 6600 nM
Beside the measured number, compound 4's estimate is 4.4-fold (0.64 log units) below it; the range from low to high includes it.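

With 3-hydroxypyrrolidin-1-yl on the saturated chain carbon, compound 4 gives a second number in this assay, so among these compounds a carboxy group on that ring is not required for a reading under the limit. The hydroxy group does not match the 3-carboxypyrrolidin-1-yl group, with a 2.9-fold higher number from compound 3 to compound 4 (0.46 log units; beyond the scatter). The other two steps, an at least 1.5-fold lower number from compound 2 to compound 4 (0.18 log units; that floor lies within the scatter) and an at least 1.5-fold lower number from compound 1 to compound 4 (0.18 log units; that floor lies within the scatter), start from limits and give only floors.

The compounds shown leave open how an unsubstituted pyrrolidin-1-yl or a 3-aminopyrrolidin-1-yl group would read at this place. They also leave open what the opposite stereocentre of 3-hydroxypyrrolidin-1-yl would give.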